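From Pyridyl Amide to Phenyl Urea on a Shared Core

A few compounds are considered here, and "the series" means these few. Any claim that something is new, unique, unknown or untested is made for them only; others in the source may bear on it.

Of the compounds shown here, three sharing one core have been tested in an assay on HEK293 cells for inhibition of protein deacetylase HDAC6 (Homo sapiens); a lower number here means a stronger inhibitor, a higher number a weaker inhibitor. Compound 1 `CCSC(=S)SCC(=O)c1ccc(NS(C)(=O)=O)cc1` gives 1090 nM. Compound 2 `CCSC(=S)SCC(=O)c1ccc(NC(=O)c2cccnc2)cc1` gives 421 nM, the second highest of the three numbers. Compound 3 `CCSC(=S)SCC(=O)c1ccc(C(=O)NCc2ccccc2)s1` gives 44 nM. It differs from the others in several places. Among the measured compounds shown here, the one step between compounds that differ in a single place runs a 2.6-fold lower number from compound 1 to compound 2 (0.41 log units; beyond the scatter), where a (pyridin-3-yl)carbonyl replaces a methylsulfonyl on the ring nitrogen.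

Compound 4 `CCSC(=S)SCC(=O)c1ccc(NC(=O)Nc2ccccc2)cc1` has not been measured. Relative to compound 2 the change is anilino in place of pyridin-3-yl on a carbonyl carbon, turning the amide into a urea. The measured step from compound 1 to compound 2 altered the group on the ring nitrogen rather than the ring hanging from the carbonyl, so it only loosely informs this change; no closer comparison exists. A small step is therefore expected for compound 4, a 1.2-fold lower number from compound 2 to compound 4 (0.08 log units; within the scatter), lying within or just beyond the scatter. Compound 4 is estimated at 350 nM, with a range from 120 nM to 1000 nM.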

Compound 4, half-maximal inhibitory concentration: 606 nM
Beside the measured number, compound 4's estimate is 1.7-fold (0.24 log units) below it; the measured number falls inside the stated range.
By their numbers in this assay, from the lowest: compound 3; then compounds 2, 4 and 1 (each within the scatter of the next, the first and the last beyond it).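

Swapping pyridin-3-yl for anilino on a carbonyl carbon turns the amide into a urea, and in this assay this gives a 1.4-fold higher number from compound 2 to compound 4 (0.16 log units; within the scatter) for the pair. Unlike the earlier step, this change acts on the ring hanging from the carbonyl, and it exchanges the hydrogen-bond acceptor of pyridin-3-yl for the hydrogen-bond donor of anilino, yet compound 2 and compound 4 cannot be told apart in this single comparison. No supporting measurement bears on this result, so it offers no explanation for it.

Going by these compounds, it remains open whether a group without an aromatic ring, such as piperidine or a simple methylamino group, would also fit at this carbonyl carbon. Compound 3 differs from these compounds in several places, so the compounds shown cannot reveal which of those differences goes with its number of 44 nM in this assay.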